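The source may hold more compounds than are shown below. What is called first, only, known or untested is meant among the compounds shown, and "the series" means these compounds.

Compound 1 `CC(C)(C)OC(=O)N1CCC(n2ncc3cc(-c4ccc(S(C)(=O)=O)cc4)ncc32)CC1`: 20 nM
Compound 2 `CCNC(=O)c1cc(F)c(-c2cc3cnn(C4CCN(C(=O)OC(C)C)CC4)c3cn2)cc1F`: 10 nM

Of the compounds shown here, two have been measured in a functional assay on HEK293 cells for agonist activity at Glucose-dependent insulinotropic receptor (Homo sapiens), read by cAMP accumulation, with a stated time of 30 min; on this read-out lower numbers stand for an effect already at smaller amounts and higher numbers for an effect only at larger amounts of compound. Compound 1 gives 20 nM in this assay, and compound 2 gives 10 nM. These two numbers sit close together, and the gap between them falls within the scatter of repeated measurements, so neither compound can be said to act at smaller amounts than the other. Compound 2 is the starting point for the next step. Compound 3 `CC(C)OC(=O)N1CCC(n2ncc3cc(-c4cc(F)c(C(=O)NCCO)cc4F)ncc32)CC1` has not yet been measured in this assay. It differs from compound 2 in one place: hydroxy in place of hydrogen on a saturated chain carbon, two bonds along the chain from an amide-type nitrogen. Within the data shown here, no measured pair shows what this kind of change does here, so the expectation rests on the structural change alone and on the value of compound 2. With no comparison to lean on, the step is expected to be small, without a clear direction, and the expected step is a 1.5-fold higher number from compound 2 to compound 3 (0.18 log units; within the scatter). For compound 3 the estimated value is 15 nM, with a range from 5 nM to 45 nM.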

Compound 3, half-maximal effective concentration: 92 nM
The estimate for compound 3 lay 6.1-fold (0.79 log units) below the measured number; measured number above the stated range.
By their numbers in this assay, from the lowest: compounds 2 and 1 (each within the scatter of the next); then compound 3.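

In this assay the change from ethylamino to (2-hydroxyethyl)amino gives a 9.2-fold higher number from compound 2 to compound 3 (0.96 log units; beyond the scatter) and so moves the result clearly beyond the usual scatter. This shows that the chain is not indifferent to change: hydroxy in place of hydrogen on a saturated chain carbon, two bonds along the chain from an amide-type nitrogen, adds only 1 heavy atom, yet larger amounts of compound are then needed for the effect. The two earlier compounds differ in more than one place, so they could not isolate any single change, whereas this pair ties the shift to this one position and this one group.

No accompanying measurement bears on the reason for this step. Going by these compounds, it also remains open whether the shift is specific to hydroxy or would follow other changes at this chain, and a methoxy group, an amine, a carboxylic acid or a longer chain in the same place would help to tell these possibilities apart.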